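Methoxy in place of methyl on the pyrrolidine aryl group

The source may hold more compounds than are shown below. What is called first, only, known or untested is meant among the compounds shown, and "the series" means these compounds.

Measured so far:
Compound 1, `COc1ccc(-n2nc(Sc3ccc(Cl)cc3)cc(CC[C@@H](C)NC(=O)[C@H]3CNC[C@@H]3c3ccc(F)cc3)c2=O)cc1`: 70 nM
Compound 2, `COc1ccc(-n2nc(Sc3ccc(Cl)cc3)cc(CC[C@@H](C)NC(=O)[C@H]3CNC[C@@H]3c3ccc(C)cc3)c2=O)cc1`: 28 nM

Of the compounds shown here, two have been tested in an assay on CHO cells for binding affinity to Melanocortin receptor 4 (Homo sapiens); on this read-out higher numbers stand for weaker inhibition and lower numbers for stronger inhibition. They share one core and differ only in the group on the aryl ring attached to the pyrrolidine: compound 1 carries fluoro there and gives 70 nM, compound 2 carries methyl and gives 28 nM. Among the measured compounds shown here, the one step on record, a 2.5-fold lower number from compound 1 to compound 2 (0.40 log units; beyond the scatter), is therefore a modest gain, and compound 2 holds the lower of the two numbers.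

Compound 3, `COc1ccc([C@H]2CNC[C@@H]2C(=O)N[C@H](C)CCc2cc(Sc3ccc(Cl)cc3)nn(-c3ccc(OC)cc3)c2=O)cc1`, is compound 2 with one change: methoxy in place of methyl on an aromatic carbon. For the measured compounds named here, no measured step exchanges methyl for methoxy at this position, so the only guide is that the single exchange seen here moved the number modestly, and methoxy is another small substituent at the same place. The change from compound 2 to compound 3 is expected to be small, a 1.3-fold higher number from compound 2 to compound 3 (0.10 log units; within the scatter), most likely within the scatter, with a weakening as plausible as a gain. Compound 3 is estimated at 35 nM, in a range from 12 nM to 100 nM.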

Compound 3, half-maximal inhibitory concentration: 19 nM
Compound 3: middle estimate off by 1.8-fold (0.27 log units), on the high side, and the stated range covers the measured number.
By their numbers in this assay, from the lowest: compounds 3 and 2 (each within the scatter of the next); then compound 1.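

In this assay the exchange of methyl for methoxy on the aromatic ring, para to a large group, gives a 1.5-fold lower number from compound 2 to compound 3 (0.17 log units; within the scatter) and so makes no difference that can be told apart from ordinary assay variation, even though the entering group brings an oxygen and one more heavy atom. Compared with fluoro at the same place, methoxy gives a 3.7-fold lower number from compound 1 to compound 3 (0.57 log units; beyond the scatter) and, together with the earlier fluoro-to-methyl step, this sets compound 1 apart from both compound 2 and compound 3, while those two cannot be ranked against each other. Nothing available explains why the fluoro compound differs from the other two.

Only fluoro, methyl and methoxy are shown at this position, so it stays open whether an ethoxy group, an amine or a carboxylic acid there would keep the number close to that of compound 3. Going by these compounds, all three compounds also share the same remaining structure, so it is equally open whether the exchange of methyl for methoxy would behave the same way on a different core.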